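Inverting the One Stereocentre of Compound 1

The source may report more compounds than this note shows. Statements on the series, on what has been measured and on what is new or still open speak of the compounds shown alone.

In an ADME assay on the whole organism for inhibition, with Oryza sativa as the target, with a stated time of 4 days (on this read-out higher numbers stand for weaker inhibition and lower numbers for stronger inhibition), compound 1 (`CCCN(CC)c1nc(Cl)nc(N[C@@H](C)c2ccccc2)n1`) gives 479 nM, the lowest of three numbers. Compound 2 (`CC[C@H](C)Nc1nc(Cl)nc(N[C@@H](C)c2ccccc2)n1`) gives 6920 nM, and compound 3 (`CCC(CC)Nc1nc(Cl)nc(N[C@@H](C)c2ccccc2)n1`) gives 35500 nM. Compound 4 (`CCCN(CC)c1nc(Cl)nc(N[C@H](C)c2ccccc2)n1`) is still unmeasured. Compared with compound 1, (the two compounds have the same atoms and bonds and differ only in configuration as drawn: 1 of 1 stereo elements differ; a stereocentre at a saturated chain carbon is drawn S in compound 1 and R in compound 4). Among the compounds with values here, no measured step touches this stereocentre. The closest evidence comes from changes to the other amino group: the large steps of a 14-fold higher number from compound 1 to compound 2 (1.16 log units; beyond the scatter) and a 74-fold higher number from compound 1 to compound 3 (1.87 log units; beyond the scatter), and the modest step of a 5.1-fold higher number from compound 2 to compound 3 (0.71 log units; beyond the scatter). One change can therefore move these numbers widely. With compound 1 already lowest, a sizeable rise is expected, though the data do not show the direction. The expected step is a 5.2-fold higher number from compound 1 to compound 4 (0.72 log units; beyond the scatter). For compound 4 the estimated value is 2500 nM, within a range of 300 nM to 20000 nM.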

Compound 4, half-maximal inhibitory concentration: 24500 nM
Compound 4: the middle estimate sits 9.8-fold (0.99 log units) below what was measured; measured number above the stated range.
By their numbers in this assay, from the lowest: compound 1; then compound 2; then compounds 4 and 3 (each within the scatter of the next).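

In this assay, redrawing the stereocentre at the saturated chain carbon from S to R brings a 51-fold higher number from compound 1 to compound 4 (1.71 log units; beyond the scatter). The earlier steps shown here all changed the other amino group, whereas this one shows that configuration at this carbon can weaken inhibition strongly without any atom entering or leaving. The whole step can be assigned to this stereocentre because nothing else changes: the fact that compounds 1 and 4 differ only in the configuration as drawn.

From the compounds shown here alone, it remains open whether the R form would cost as much alongside the sec-butylamino or pentan-3-ylamino group. Also open, going by these compounds, is how a longer chain or a carboxylic acid on this carbon would behave.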